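Three Analogues at the Assay Limit and a Fourth Untested

The source may hold more compounds than are shown below. What is called first, only, known or untested is meant among the compounds shown, and "the series" means these compounds.

Compound 1, `CS(=O)(=O)c1ccc(C(=O)N2CCC(C(=O)N(Cc3ccccc3)c3ccccc3)CC2)cc1[N+](=O)[O-]`: in an assay on isolated protein for inhibition of vitamin D3 receptor (Homo sapiens), read by fluorescence polarization (on this read-out lower numbers stand for stronger inhibition and higher numbers for weaker inhibition), compound 1 gives > 60000 nM, which is a limit of the assay rather than a number.
Compound 2, `CS(=O)(=O)c1ccc(C(=O)NCCC(=O)N2CCCCC2)cc1[N+](=O)[O-]`: in this assay compound 2 gives > 60000 nM, again a limit of the assay.
Compound 3, `CS(=O)(=O)c1ccc(C(=O)NCCC(=O)N2CCc3ccccc32)cc1[N+](=O)[O-]`: in this assay compound 3 gives > 60000 nM, again a limit of the assay.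

Compound 1 therefore has no measured number of its own; it sits at the limit of > 60000 nM in this assay, at which 3 of the 3 values shown sit, the same limit at which every value shown here rests. For the measured compounds named here, the only pair of measured compounds that differ in a single place gives a step that the two limits leave unreadable from compound 2 to compound 3, so no direction or size can be taken from it.

Compound 4, `CN(Cc1ccccc1)C(=O)C1CCN(C(=O)c2ccc(S(C)(=O)=O)c([N+](=O)[O-])c2)CC1`, is drawn from compound 1 by a single change: methyl in place of phenyl on an amide-type nitrogen. Going by the values given here, none of the measured steps touches this kind of change, and the one step that exists between measured compounds cannot be read, so the data give no footing for expecting a shift in either direction beyond the scatter.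

The step from compound 1 to compound 4 is thus expected to be a step that the limit leaves unreadable from compound 1 to compound 4, meaning essentially nothing that can be resolved. Compound 4 is accordingly expected to give about 100000 nM, with a range from 30000 nM to 300000 nM, and most likely to be reported only as a limit.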

Compound 4, half-maximal inhibitory concentration: > 60000 nM
Compound 4: no number, only a limit (the forecaster's own chance of this, stated with the estimate: 85%); the middle value does not contradict the limit.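

Compound 4 gives only a limit of the assay, as compound 1 does, so no step can be read for methyl in place of phenyl on the amide-type nitrogen: the limit of > 60000 nM in this assay, at which 4 of the 4 values shown sit. The compounds shown leave open whether any change to them can alter inhibition, with no true number yet available for comparison.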